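Swapping Methyl for Isopropoxy in an Antiproliferative Series

A few compounds are considered here, and "the series" means these few. Any claim that something is new, unique, unknown or untested is made for them only; others in the source may bear on it.

Compound 1 (`COc1cc(-n2ncnc2-c2ccc(C)cc2)cc(OC)c1OC`) has been tested in a functional assay on MCF7 cells (Homo sapiens) for antiproliferative activity, read by MTT assay, with a stated time of 72 h; on this read-out higher numbers stand for weaker inhibition and lower numbers for stronger inhibition. In this assay, within the data shown here, compound 1 gives 540 nM, the only true number available so far. Compound 2 (`COc1cc(-c2ncnn2-c2cccc(N)c2)cc(OC)c1OC`) gives only a limit of the assay, > 10000 nM. Compound 3 (`COc1cc(-n2ncnc2-c2cccc([N+](=O)[O-])c2)cc(OC)c1OC`) likewise gives only a limit, > 10000 nM. Compound 1 is therefore the single measured point in this small set, and the rest of the picture is the limit of > 10000 nM in this assay, at which 2 of the 3 values shown sit.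

Compound 4 (`COc1cc(-n2ncnc2-c2ccc(OC(C)C)cc2)cc(OC)c1OC`) keeps the core of compound 1 and changes one group: isopropoxy in place of methyl on an aromatic carbon. Isopropoxy takes the place of methyl on an aromatic carbon, para to a large group. Among the measured compounds shown here, no pair of measured compounds shows what this swap does, so any forecast here is a loose one. Starting from compound 1 at 540 nM, a loss of inhibition seems likelier than a gain, though a result within the scatter would be no surprise. The expected change is moderate, an estimated 2.8-fold higher number from compound 1 to compound 4 (0.44 log units; beyond the scatter). The estimated value for compound 4 is 1500 nM, with an expected range from 250 nM to 9000 nM.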

Compound 4, half-maximal inhibitory concentration: 610 nM
The estimate for compound 4 lay 2.5-fold (0.39 log units) above the measured number; the measured number falls inside the stated range.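

In this assay, isopropoxy in place of methyl on an aromatic carbon, para to a large group, gives a 1.1-fold higher number from compound 1 to compound 4 (0.05 log units; within the scatter). Among these compounds, this is the first readable step in the set, and it shows that this position accepts a much larger group with no measurable effect on the read-out: the entering group has 4 heavy atoms against 1 for methyl, and it brings an oxygen and a hydrogen-bond acceptor that methyl lacks. Compound 1 alone could not show this, since a single measured number says nothing about how much room for change a position has.

The compounds shown do not tell how far this acceptance extends, for instance whether a carboxylic acid, a fluorine atom or a longer alkoxy chain in the same place would leave the number just as unmoved. Compound 2 and compound 3 add no readable step to this picture, because each stands only as a limit of the assay: the limit of > 10000 nM in this assay, at which 2 of the 4 values shown sit.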